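Swapping a benzyl for a phenoxy group and the acid dissociation constant

This account rests on a few compounds, and the source may have more. Where it says the series, first, only, none or still open, it means among the compounds named here.

Three compounds sharing one core have been examined in a physicochemical assay for acid dissociation. Compound 1, `COc1ccc(Oc2ccc3c(NCCCNCc4cccc(OC)c4O)ccnc3c2)cc1`, gives 9.28. Compound 2, `COc1cccc(CNCCCNc2ccnc3cc(Oc4ccc(C(C)(C)C)cc4)ccc23)c1O`, gives 9.28. Compound 3, `COc1cccc(CNCCCNc2ccnc3cc(Cc4cc(C)cc(C)c4)ccc23)c1O`, gives 9.47. Compound 3 has the highest of the three numbers, but its nearest neighbour is compound 1 and its furthest is compound 2, and both of those sit only a small distance away: a number 0.19 log units higher from compound 1 to compound 3 (within the scatter) and a number 0.19 log units higher from compound 2 to compound 3 (within the scatter), each within the scatter. The step of no change at the digits printed from compound 1 to compound 2 (within the scatter) shows that exchanging one group on the far aromatic ring for another also left the number alone.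

Compound 4, `COc1ccccc1Oc1ccc2c(NCCCNCc3cccc(OC)c3O)ccnc2c1`, has not yet been measured. It differs from compound 3 in one place: 2-methoxyphenoxy in place of 3,5-dimethylbenzyl on an aromatic carbon. This is the reverse of what was done from compound 1 and compound 2 to compound 3, where a phenoxy group gave way to the 3,5-dimethylbenzyl group; both of those steps were small and within the scatter. Putting a phenoxy group back is therefore expected to move the number by about the same small amount, if at all, so the step of a number 0.19 log units lower from compound 3 to compound 4 (within the scatter) is expected to stay within the scatter. For compound 4 the estimate in this assay is 9.28, expected to fall between 8.98 and 9.58.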

Compound 4, acid dissociation constant: 9.28
Compound 4: middle estimate and measured number agree at the digits printed, within the range that was stated.
By their numbers in this assay, from the lowest: compounds 1, 2, 4 and 3 (each within the scatter of the next).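

In this assay the new compound tests something the earlier ones could not: whether a group holding oxygen atoms, 2-methoxyphenoxy with 2 hydrogen-bond acceptors, reads differently from the all-carbon 3,5-dimethylbenzyl with 0 acceptors, when both have 9 heavy atoms and sit on the same aromatic carbon, and the swap gives a number 0.19 log units lower from compound 3 to compound 4 (within the scatter). It also adds a methoxy group at a new place on the outer ring of the phenoxy substituent, since the phenoxy compounds before it carried only 4-substituted rings, yet replacing 4-(tert-butyl)phenyl on the oxygen gives no change at the digits printed from compound 2 to compound 4 (within the scatter) and replacing 4-methoxyphenyl gives no change at the digits printed from compound 1 to compound 4 (within the scatter). Across these four compounds, then, no exchange at this position produces a step beyond the scatter, whether the linking atom is the oxygen of a phenoxy group or the carbon of a benzyl group and wherever the outer ring carries its substituents.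

As far as these compounds go, whether an amine or a carboxylic acid on this aromatic carbon would shift the number remains open, as does the effect of a longer chain in the side arm of the shared core. Nothing available here explains why these numbers lie so close together.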